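A few compounds are considered here, and "the series" means these few. Any claim that something is new, unique, unknown or untested is made for them only; others in the source may bear on it.

Measured in a functional assay on MDA-MB-231 cells (Homo sapiens) for antiproliferative activity, read by MTT assay, with a stated time of 48 h; a higher number here means a weaker inhibitor, a lower number a stronger inhibitor:
- compound 1 `CN1CCN(c2ccc(-c3cc4c(N5CCN(C(=O)Nc6ccc(Cl)cc6)CC5)ncnc4s3)cc2)CC1`: 5440 nM
- compound 2 `CN1CCN(c2ccc(-c3cc4c(N5CCN(C(=O)Nc6ccc(OC(F)(F)F)cc6)CC5)ncnc4s3)cc2)CC1`: 4600 nM

Only these two numbers exist so far, and compound 2 stands at 4600 nM. Within the data shown here, the single measured step is a 1.2-fold lower number from compound 1 to compound 2 (0.07 log units; within the scatter). That change, trifluoromethoxy in place of chloro on an aromatic carbon, leaves the two compounds indistinguishable in this assay.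

Compound 3 `CC(C)c1cccc(C(C)C)c1NC(=O)N1CCN(c2ncnc3sc(-c4ccc(N5CCN(C)CC5)cc4)cc23)CC1` carries 2,6-diisopropylphenyl in place of 4-(trifluoromethoxy)phenyl on an amide-type nitrogen. This is a larger kind of change than the measured one, which swapped one group on the ring and left the ring in place. Among the measured compounds shown here, the earlier step is therefore only a loose guide, and no measured compound yet shows what a change of this kind does. Going by these compounds, no step beyond the scatter is expected, and the direction remains open, so the range has to stay wide.

The expected change is a 1.3-fold higher number from compound 2 to compound 3 (0.12 log units; within the scatter). For compound 3 the estimated value is 6000 nM, with an expected range of 2000 nM to 18000 nM.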

Compound 3, half-maximal inhibitory concentration: 8430 nM
Estimate against measurement, compound 3: 1.4-fold (0.15 log units) below; the range from low to high includes it.
By their numbers in this assay, from the lowest: compounds 2, 1 and 3 (each within the scatter of the next).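

In this assay putting 2,6-diisopropylphenyl in place of 4-(trifluoromethoxy)phenyl on the amide-type nitrogen gives a 1.8-fold higher number from compound 2 to compound 3 (0.26 log units; within the scatter) and putting it in place of 4-chlorophenyl gives a 1.5-fold higher number from compound 1 to compound 3 (0.19 log units; within the scatter) with the same group entering both times. Until now this position had shown only a swap of one group on the ring, whereas here the substituted phenyl group is exchanged as a whole, and still no step leaves the scatter, so the three compounds cannot be told apart in this read-out. Nothing at hand explains why a change of this size leaves the number within the scatter.

All three compounds keep a benzene ring on this nitrogen, so the compounds shown leave open what happens when a pyridine ring, a plain alkyl chain or a group carrying a carboxylic acid stands there instead. They also leave open whether any group at this position can move the number beyond the scatter at all.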